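Dropping a Sulfur-Bearing Group: What Compound 4 Might Show

This account rests on a few compounds, and the source may have more. Where it says the series, first, only, none or still open, it means among the compounds named here.

Three compounds of this series share a core in which a large, branched hydrocarbon part is joined to a six-membered non-aromatic ring carrying two carbonyl groups. Compound 1 `CCCCSC1=CC(=O)C(C[C@]2(C)[C@@H](C)CC[C@]3(C)C(C)=CCC[C@@H]23)=CC1=O` and compound 2 `CCCSC1=CC(=O)C(C[C@]2(C)[C@@H](C)CC[C@]3(C)C(C)=CCC[C@@H]23)=CC1=O` differ from each other only in the chain attached through sulfur to that ring. For compound 1 the result in an ADME assay on PBMC cells (Homo sapiens) for cytotoxicity, read by MTT assay (a higher number here means a weaker inhibitor, a lower number a stronger inhibitor), is recorded as "not determined" (no result reported), and for compound 2 the entry in this assay is likewise "not determined" (no result reported). For the measured compounds named here, compound 3 `CC1=CCC[C@H]2[C@](C)(CC3=CC(=O)C(SC(C)(C)C)=CC3=O)[C@@H](C)CC[C@]12C` carries a (tert-butyl)sulfanyl group at the same position and is the only member with a number: in this assay compound 3 gives 21700 nM, a weak effect on these blood cells.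

Compound 4 `CC1=CCC[C@H]2[C@](C)(CC3=CC(=O)C=CC3=O)[C@@H](C)CC[C@]12C` is the bare core: the change from compound 3 is hydrogen in place of (tert-butyl)sulfanyl on a double-bonded ring carbon. Going by the values given here, no measured pair in this set shows what such a removal does, so the expected step from compound 3 to compound 4 is estimated as a 1.8-fold lower number from compound 3 to compound 4 (0.26 log units; within the scatter), leaning toward a somewhat stronger effect but with wide uncertainty. Compound 4 is therefore expected to give roughly 12000 nM in this assay, within a range from 3000 nM to 50000 nM.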

Compound 4, half-maximal inhibitory concentration: 4800 nM
The estimate for compound 4 lay 2.5-fold (0.40 log units) above the measured number; the measured number falls inside the stated range.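

For the compounds shown here, replacing (tert-butyl)sulfanyl with hydrogen on a double-bonded ring carbon gives the first readable step at this position: in this assay, the result is a 4.5-fold lower number from compound 3 to compound 4 (0.66 log units; beyond the scatter). Since a lower number here means a stronger effect on these blood cells, the bare core of compound 4 is the stronger of the two, and the sulfur-bearing group is not needed for the core to act on these cells; what sits on this ring carbon does change the reading, though the step is modest in size. Nothing available here explains why the number falls when this group leaves.

Going by these compounds alone, the entries for compound 1 and compound 2 give no number, so no step involving their sulfur-linked chains can be read, and a single pair cannot show whether any sulfur-linked group would lower or raise the number relative to hydrogen. Going by these compounds, how an amine, a carboxylic acid or a simple methyl group on this same ring carbon would compare with both hydrogen and (tert-butyl)sulfanyl remains open.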